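Swapping a thiophene substituent on two related fused cores

The source may report more compounds than this note shows. Statements on the series, on what has been measured and on what is new or still open speak of the compounds shown alone.

Measured compounds:
- compound 1, `Cc1cc(-c2nc3sc(C)cn3c2/C=N/NC(=N)N)c(C)s1`: 7410 nM
- compound 2, `Cc1cn2c(/C=N/NC(=N)N)c(-c3cccs3)nc2s1`: 2240 nM
- compound 3, `Cc1cc(-c2nc3n(c2/C=N/NC(=N)N)CCS3)c(C)s1`: 15500 nM

The three measured compounds were tested in a functional assay on cells (Melanoma cell, Homo sapiens) for inhibition; a higher number here means a weaker inhibitor of growth, a lower number a stronger inhibitor of growth. Compound 1 and compound 2 share one core and differ only in the group on an aromatic carbon: thiophen-2-yl in place of 2,5-dimethylthiophen-3-yl on an aromatic carbon. This change gave a 3.3-fold lower number from compound 1 to compound 2 (0.52 log units; beyond the scatter). Compound 3 carries the same 2,5-dimethylthiophen-3-yl group on a different core; the difference between the two cores is not broken down here. In this assay compound 3 gives the highest number of the three, with compound 1 nearest and compound 2 furthest.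

Compound 4, `N=C(N)N/N=C/c1c(-c2cccs2)nc2n1CCS2`, has not yet been measured. It differs from compound 3 in the same kind of change that separates compound 1 from compound 2: thiophen-2-yl in place of 2,5-dimethylthiophen-3-yl on an aromatic carbon. The surroundings of the place are not identical, though: in compound 3 the carbon bearing the group also sits two ring bonds from two ring atoms that each bear a fused ring, which is not part of the description for compound 1.

Because the change from compound 1 to compound 2 gave a 3.3-fold lower number from compound 1 to compound 2 (0.52 log units; beyond the scatter), a step of similar size and direction is expected here, and the estimate for compound 4 means a 3.3-fold lower number from compound 3 to compound 4 (0.52 log units; beyond the scatter) in this assay. This rests on a single earlier example on another core, so the expectation is held loosely. Compound 4 is expected to give about 4700 nM in this assay, with a plausible range from 1800 nM to 12000 nM.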

Compound 4, concentration for 50% growth inhibition: 21400 nM
Compound 4: middle estimate off by 4.6-fold (0.66 log units), on the low side; measured number outside the range, above it.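

In this assay, the swap of 2,5-dimethylthiophen-3-yl for thiophen-2-yl did not repeat its earlier result on the core of compound 3: it gave a 1.4-fold higher number from compound 3 to compound 4 (0.14 log units; within the scatter), so on this core the step is too small to separate the two groups. Set side by side, the two results differ by more than repeated measurement would explain, which means the outcome of this change depends on the core that carries it: the same change on two cores in this assay, a 3.3-fold lower number (0.52 log units; beyond the scatter) from compound 1 to compound 2 and a 1.4-fold higher number (0.14 log units; within the scatter) from compound 3 to compound 4, 4.6-fold (0.66 log units) apart, beyond the scatter of two such steps. Among the compounds shown here, the stronger growth inhibition seen on the core of compound 1 therefore cannot simply be carried over to the core of compound 3, but with only one pair on each core, these results do not show which feature of the two cores is responsible, or how the change would behave on a further core.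

The compounds shown leave open whether other groups in this place, such as a phenyl ring, a methyl group or an amine, would also behave differently on the two cores. They also leave open whether a thiophene bearing a single methyl group would follow the pattern of either core.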